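The compounds below may be only part of what the source reports. "The series", "measured", "known", "first", "only" and "open" are said of these compounds alone.

Compound 1 (`COc1cccc(Cc2cc(C(C)C)nn(CC(=O)Nc3ccc(Br)cc3)c2=O)c1`) was tested in a functional assay on HL-60 cells (Homo sapiens), read by calcium flux; a lower number here means that less compound is needed, a higher number that more compound is needed for the effect. Compound 1 gives > 50000 nM there, which is a limit of the assay and not a number. Compound 2 (`COc1cccc(Cc2cc(-c3ccccc3)nn(CC(=O)Nc3ccc(Br)cc3)c2=O)c1`) carries a phenyl in place of the isopropyl on an aromatic carbon. In this assay compound 2 gives > 50000 nM, again a limit. Compound 3 (`COc1cccc(Cc2cc(-c3ccccc3)nn(CC(=O)Nc3ccc(F)cc3)c2=O)c1`) carries a fluoro in place of the bromo on an aromatic carbon. In this assay compound 3 gives > 50000 nM, also a limit. The step that the two limits leave unreadable from compound 1 to compound 2 and the step that the two limits leave unreadable from compound 2 to compound 3 therefore cannot be sized, because of the limit of > 50000 nM in this assay, at which 3 of the 3 values shown sit. Compound 3 thus stands where every value shown stands, at the same limit, with no number to place it.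

Compound 4 (`COc1cccc(Cc2cc(-c3cccs3)nn(CC(=O)Nc3ccc(F)cc3)c2=O)c1`) differs from compound 3 by thiophen-2-yl in place of phenyl on an aromatic carbon. No measured step bears directly on this change; the two steps shown were both unreadable, and no step from any value in the scatter is available. In this assay compound 4 is therefore expected to sit near the limit as well, with the expected step that the limit leaves unreadable from compound 3 to compound 4 not readable beyond the scatter. The estimate for compound 4 is 60000 nM, ranging from 20000 nM to 200000 nM.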

Compound 4, half-maximal effective concentration: > 50000 nM
Compound 4: a limit, no number (the forecaster's own chance of this, stated with the estimate: 85%); the middle value does not contradict the limit.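

In this assay compound 3 and compound 4 both sit at a limit and not at a number, so no size can be read for the change between them: the limit of > 50000 nM in this assay, at which 4 of the 4 values shown sit. The compounds shown leave open whether any change to the shared core would give a readable number in this assay.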